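An Ester Replaced by an Ether Side Chain

A few compounds are considered here, and "the series" means these few. Any claim that something is new, unique, unknown or untested is made for them only; others in the source may bear on it.

Compound 1 `CCCCC(O)CC(=O)O[C@H](CC=C(C)C)C1=CC(=O)c2c(O)ccc(O)c2C1=O` gives 45300 nM in a functional assay on DU-145 cells (Homo sapiens) for cytotoxicity, read by MTT assay; a higher number here means a weaker inhibitor, a lower number a stronger inhibitor.
Compound 2 `COCCO[C@H](CC=C(C)C)C1=CC(=O)c2c(O)ccc(O)c2C1=O` gives 43200 nM in this assay.
Compound 3 `CC(C)=CC[C@@H](OC(=O)C1CCCOC1)C1=CC(=O)c2c(O)ccc(O)c2C1=O` gives 29700 nM in this assay.

Compound 1 sits at the upper end of these three numbers, yet its gaps to the other two, a 1.0-fold lower number from compound 1 to compound 2 (0.02 log units; within the scatter) and a 1.5-fold lower number from compound 1 to compound 3 (0.18 log units; within the scatter), both lie within the scatter. Compound 4 `CCC(CO[C@H](CC=C(C)C)C1=CC(=O)c2c(O)ccc(O)c2C1=O)OC` differs from compound 1 by 2-methoxybutyl in place of (2-hydroxyhexyl)carbonyl on an oxygen on a saturated carbon. Going by the values given here, the closest precedent is a 1.0-fold lower number from compound 1 to compound 2 (0.02 log units; within the scatter), which also put an ether in place of the ester on that same oxygen; a 1.5-fold lower number from compound 2 to compound 3 (0.16 log units; within the scatter) likewise stayed within the scatter. No step beyond the scatter is therefore expected in this assay for compound 4. Compound 4 is expected to give 40000 nM, between 20000 nM and 85000 nM. The expected step is a 1.1-fold lower number from compound 1 to compound 4 (0.05 log units; within the scatter).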

Compound 4, half-maximal inhibitory concentration: 45700 nM
Estimate against measurement, compound 4: 1.1-fold (0.06 log units) below; measured number inside the range.
By their numbers in this assay, from the lowest: compounds 3, 2, 1 and 4 (each within the scatter of the next).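

Adding an ethyl to the ether chain of compound 2 leaves the number in this assay within the scatter (a 1.1-fold higher number from compound 2 to compound 4 (0.02 log units; within the scatter)). The 2-methoxybutyl ether of compound 4 also stays within the scatter of both esters on this oxygen, the open-chain one (a 1.0-fold higher number from compound 1 to compound 4 (0.00 log units; within the scatter)) and the ring-bearing one (a 1.5-fold higher number from compound 3 to compound 4 (0.19 log units; within the scatter)), so all four side chains read alike here. No measurement available here explains this flat result.

On these data alone, whether an amine or a carboxylic acid on this side chain would produce a step beyond the scatter remains open.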